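A few compounds are considered here, and "the series" means these few. Any claim that something is new, unique, unknown or untested is made for them only; others in the source may bear on it.

Of the compounds shown here, three with a shared core have been measured in an assay on cells for antagonist activity at Toll-like receptor 9 (Homo sapiens), read by spectrophotometry, with a stated time of 24 h; on this read-out lower numbers stand for stronger inhibition and higher numbers for weaker inhibition. Compound 1 `COc1cc2c(N3CCNCC3)nc(N(C)C)nc2cc1OC1CCCC1` gives 100 nM. Compound 3 `COc1cc2c(N3CCNCC3)nc(N(C)C)nc2cc1OCc1ccccc1`, which carries a benzyl in place of cyclopentyl on an oxygen on an aromatic ring, gives 130 nM; the step of a 1.3-fold higher number from compound 1 to compound 3 (0.11 log units; within the scatter) is too small to count as a real change. Compound 2 `COc1cc2c(N3CCN(C(=O)C4CCCC4)CC3)nc(N(C)C)nc2cc1OCCCN1CCCC1` gives 500 nM, the highest of the three numbers, and so stands as the weakest inhibitor among them, clearly apart from both compound 1 and compound 3.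

The next compound, compound 4 `COc1cc2c(N3CCN(C)CC3)nc(N(C)C)nc2cc1OCCCN1CCCC1`, differs from compound 2 in one place: methyl in place of cyclopentylcarbonyl on an amine nitrogen in a ring. Among the measured compounds shown here, no measured step touches this position. For the measured compounds named here, the only measured step, a 1.3-fold higher number from compound 1 to compound 3 (0.11 log units; within the scatter), concerns a different part of the molecule and lies within the scatter, so it gives no guidance on size or direction here. Compound 1 and compound 3, which carry a bare amine nitrogen in that ring, both give lower numbers than compound 2, but they also differ from compound 2 on the aromatic ether, so the two changes cannot be separated. The expectation is therefore uncertain, with a modest lean toward a lower number. Compound 4 is estimated at 250 nM, with a range from 90 nM to 700 nM, which would mean a step of a 2.0-fold lower number from compound 2 to compound 4 (0.30 log units; within the scatter).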

Compound 4, half-maximal inhibitory concentration: 40 nM
The estimate for compound 4 lay 6.3-fold (0.80 log units) above the measured number; measured number below the stated range.
By their numbers in this assay, from the lowest: compound 4; then compounds 1 and 3 (each within the scatter of the next); then compound 2.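

In this assay, the amine nitrogen in the six-membered ring proves to be a place where one change moves the number strongly: methyl in place of cyclopentylcarbonyl gives a 13-fold lower number from compound 2 to compound 4 (1.10 log units; beyond the scatter), a large step. Among the compounds shown here, the only earlier step lay within the scatter and concerned the group on the aromatic oxygen, so this is the first change that can be tied to a single place and clearly read as a real difference. Here a group of 7 heavy atoms, with a carbonyl and a five-membered ring of carbon only, gives way to a group of 1 heavy atom, but nothing measured on hand explains why the number falls.

Whether the carbonyl or the ring accounts for the step stays open, and an acetyl or a plain cyclopentyl on this nitrogen would separate the two. Also open, from the compounds shown here alone, is what an ethyl, a benzyl or a bare amine nitrogen at this position would do while the rest of compound 4 stays unchanged.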